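Taking the isopropyl group off compound 2

The source may report more compounds than this note shows. Statements on the series, on what has been measured and on what is new or still open speak of the compounds shown alone.

Compound 1 `CC(C)c1[nH]cnc1/C=c1\[nH]c(=O)/c(=C/c2cccc(Oc3ccc(F)cc3)c2)[nH]c1=O`: 8.8 nM
Compound 2 `CC(C)c1[nH]cnc1/C=c1\[nH]c(=O)/c(=C/c2cccc(C(=O)c3ccc(F)cc3)c2)[nH]c1=O`: 3.2 nM
Compound 3 `Cc1[nH]cnc1/C=c1\[nH]c(=O)/c(=C/c2cccc(Oc3ccc(F)cc3)c2)[nH]c1=O`: 47.6 nM

All three values come from a functional assay on NCI-H460 cells (Homo sapiens) for cytotoxicity, read by MTT assay, with a stated time of 72 h; a higher number here means a weaker inhibitor, a lower number a stronger inhibitor. Among them, compound 2 stands lowest at 3.2 nM, and its separation from each of the other two lies beyond the scatter. Its edge over the first compound is a 2.8-fold lower number from compound 1 to compound 2 (0.44 log units; beyond the scatter), a change of (4-fluorophenyl)carbonyl in place of 4-fluorophenoxy. That change lies at a different place from the one examined here, so it fixes the starting point and says nothing further about the new step.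

Compound 4 `O=C(c1ccc(F)cc1)c1cccc(/C=c2\[nH]c(=O)/c(=C/c3c[nH]cn3)[nH]c2=O)c1` differs from compound 2 in one place: hydrogen in place of isopropyl on an aromatic carbon. In words, this is hydrogen in place of isopropyl on an aromatic carbon.

Among the compounds with values here, the only measured change at that carbon is a 5.4-fold higher number from compound 1 to compound 3 (0.73 log units; beyond the scatter), with methyl in place of isopropyl, and it raised the number beyond the scatter. Within the data shown here, no measured compound carries hydrogen there, and that step was seen alongside 4-fluorophenoxy, so carrying it over is an extrapolation. Hydrogen removes the whole isopropyl group, so a rise of similar or larger size is expected in this assay.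

The expected size of the change is a 13-fold higher number from compound 2 to compound 4 (1.10 log units; beyond the scatter). For compound 4 the estimated value is 40 nM, with an expected range from 12 nM to 150 nM.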

Compound 4, half-maximal inhibitory concentration: 278 nM
Estimate against measurement, compound 4: 7.0-fold (0.84 log units) below, outside the stated range (above it).
By their numbers in this assay, from the lowest: compound 2; then compound 1; then compound 3; then compound 4.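

In this assay, removing the isopropyl group altogether gives an 87-fold higher number from compound 2 to compound 4 (1.94 log units; beyond the scatter), which shows that the number depends heavily on what sits on this aromatic carbon of the five-membered aromatic ring with 2 nitrogen, and that this holds with (4-fluorophenyl)carbonyl on the far side of the shared core as well as with 4-fluorophenoxy. The earlier step, a 5.4-fold higher number from compound 1 to compound 3 (0.73 log units; beyond the scatter), was modest where this one is large, so the two together fit a loss that grows as the group shrinks from isopropyl through methyl to hydrogen, though they rest on different compounds and do not form a single series. Nothing given here accounts for the size of this loss.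

The compounds shown leave open where methyl would fall on the (4-fluorophenyl)carbonyl compound, and where hydrogen would fall on the 4-fluorophenoxy compound, so the two steps cannot yet be set on one common partner. They also leave open how a longer chain such as n-butyl, a cyclopropyl ring or an amine on the same carbon would compare with isopropyl.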